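A few compounds are considered here, and "the series" means these few. Any claim that something is new, unique, unknown or untested is made for them only; others in the source may bear on it.

For the measured compounds named here, compound 3, `COc1cc(-c2ccnc3cc(-c4ccc(C(C)=O)cc4)nn23)cc(OC)c1OC`, sits at the top of the three numbers so far: in a functional assay on A549 cells (Homo sapiens) for inhibition, read by CCK-8 assay, with a stated time of 48 h (a lower number here means a stronger inhibitor, a higher number a weaker inhibitor), compound 3 gives 4100 nM, close to compound 2, `COc1cc(-c2ccnc3cc(-c4ccc(Cl)cc4)nn23)cc(OC)c1OC`, which gives 3070 nM, and far from compound 1, `COc1cc(-c2ccnc3cc(-c4ccc(C)cc4)nn23)cc(OC)c1OC`, which gives 3 nM. The next compound is compound 4, `COc1cc(-c2ccnc3cc(-c4ccc(-c5cnn(C)c5)cc4)nn23)cc(OC)c1OC`. It differs from compound 3 in one place: 1-methyl-1H-pyrazol-4-yl in place of acetyl on an aromatic carbon. Two earlier steps touch this position. Replacing methyl gave a 1400-fold higher number from compound 1 to compound 3 (3.14 log units; beyond the scatter) and a 1000-fold higher number from compound 1 to compound 2 (3.01 log units; beyond the scatter), while exchanging the two non-methyl groups gave a 1.3-fold higher number from compound 2 to compound 3 (0.13 log units; within the scatter). Going by the values given here, no earlier step introduced a ring here, so the outcome is uncertain, but both non-methyl groups so far gave weak inhibition. Compound 4 is therefore expected to give about 2500 nM, within 300 nM to 20000 nM. This estimate means a step for compound 4 of a 1.6-fold lower number from compound 3 to compound 4 (0.21 log units; within the scatter), expected to stay within the scatter.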

Compound 4, half-maximal inhibitory concentration: 1150 nM
Compound 4: middle estimate off by 2.2-fold (0.34 log units), on the high side; the range from low to high includes it.
By their numbers in this assay, from the lowest: compound 1; then compound 4; then compounds 2 and 3 (each within the scatter of the next).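

The first ring placed at this position, 1-methyl-1H-pyrazol-4-yl, does better than either earlier replacement of methyl, with a 3.6-fold lower number from compound 3 to compound 4 (0.55 log units; beyond the scatter) and a 2.7-fold lower number from compound 2 to compound 4 (0.43 log units; beyond the scatter) beyond the scatter, so the non-methyl groups do not all behave alike. It still recovers only a small part of the loss, since there is a 380-fold higher number from compound 1 to compound 4 (2.58 log units; beyond the scatter) and methyl stays far ahead of the other three groups. Nothing measured here gives a reason for these differences. As far as these compounds go, whether ethyl or methoxy would come close to compound 1 remains open, as does whether a pyridine ring would improve on compound 4.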